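Phenyl for dimethylamino on a weakly inhibiting core

The source may report more compounds than this note shows. Statements on the series, on what has been measured and on what is new or still open speak of the compounds shown alone.

Measured compounds:
compound 1 `CN(C)c1c(C#N)c2c(N)ncnc2n1C` gives 4620 nM
compound 2 `Cc1c(Nc2nc(N)c3c(C#N)c(N4CCC[C@H]4C)n(C)c3n2)cnn1[C@H]1CCOC1` gives 23 nM

Both compounds were tested in an assay on isolated protein for inhibition of Leucine-rich repeat serine/threonine-protein kinase 2 (Homo sapiens), read by TR-FRET and LanthaScreen, with stated times of 50 min and 30 min, in the presence of a further agent that is not named here; on this read-out higher numbers stand for weaker inhibition and lower numbers for stronger inhibition. Compound 1 stands at the higher of the two numbers: in this assay compound 1 gives 4620 nM, while compound 2, built on the same core but carrying several further groups, gives 23 nM, a difference that lies well beyond the usual scatter. Since the two compounds differ in more than one place, the gap cannot be tied to any single group.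

Compound 3 `Cn1c(-c2ccccc2)c(C#N)c2c(N)ncnc21` has not yet been measured. It differs from compound 1 in one place: phenyl in place of dimethylamino on an aromatic carbon of the shared core. Among the measured compounds shown here, no measured pair shows this exchange, so there is no precedent here for its size or direction. The step this estimate means, a 1.5-fold lower number from compound 1 to compound 3 (0.19 log units; within the scatter), is expected to be small, within or close to the scatter. For compound 3 the estimated value in this assay is 3000 nM, with a range from 700 nM to 13000 nM.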

Compound 3, half-maximal inhibitory concentration: 1260 nM
Compound 3: the middle estimate sits 2.4-fold (0.38 log units) above what was measured, within the range that was stated.
By their numbers in this assay, from the lowest: compound 2; then compound 3; then compound 1.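

At the aromatic carbon next to the ring nitrogen, the exchange of dimethylamino for phenyl gives a 3.7-fold lower number from compound 1 to compound 3 (0.56 log units; beyond the scatter) in this assay, the first step read at this position on the shared core. It shows that this place accepts a six-membered aromatic ring of carbon only, and that the number falls modestly even though the hydrogen-bond acceptor counted for dimethylamino leaves with the exchange. Nothing measured here bears on why the number changes with this exchange.

Going by these compounds, whether the lower number is specific to phenyl remains open, since a single exchange cannot show how a morpholine on the same carbon, or a methoxy or fluorine group on the phenyl ring, would compare. Also open, on these data alone, is whether the exchange would keep its direction and size on a core carrying the further groups of compound 2, where the effect of phenyl at this position could differ from its effect on the core of compound 1.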